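This account rests on a few compounds, and the source may have more. Where it says the series, first, only, none or still open, it means among the compounds named here.

Compound 1 `CCCCCCCCCCn1cc(/C=C/C(=O)c2ccc(NC(=O)CN3CCN(C(=O)OC(C)(C)C)CC3)cc2)nn1` and compound 2 `CC(C)(C)OC(=O)N1CCN(CC(=O)Nc2ccc(C(=O)/C=C/c3cn(Cc4ccc(Br)cc4)nn3)cc2)CC1` share one core. In a functional assay on SK-N-SH cells (Homo sapiens) for inhibition, read by MTT assay (a higher number here means a weaker inhibitor, a lower number a stronger inhibitor), compound 1 gives 77800 nM, the highest of the two numbers, while compound 2 gives 25800 nM, so a 3.0-fold lower number from compound 1 to compound 2 (0.48 log units; beyond the scatter). Compound 3 `CCCCCCCCCCn1cc(/C=C/C(=O)c2ccc(NC(=O)CN3CCN(c4ccccc4)CC3)cc2)nn1` differs from compound 1 by phenyl in place of tert-butoxycarbonyl on an amine nitrogen in a ring. Among the compounds with values here, that single measured step changed a different part of the molecule and says nothing about the ring nitrogen, so no step bears directly on this change; the expected result in this assay is a change of uncertain direction, likely within the scatter. Compound 3 is therefore estimated at 55000 nM (range 15000 nM to 150000 nM), an expected step of a 1.4-fold lower number from compound 1 to compound 3 (0.15 log units; within the scatter).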

Compound 3, half-maximal inhibitory concentration: 39500 nM
The estimate for compound 3 lay 1.4-fold (0.14 log units) above the measured number; low and high end bracket the measured number.
By their numbers in this assay, from the lowest: compounds 2, 3 and 1 (each within the scatter of the next, the first and the last beyond it).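

At the ring nitrogen, phenyl in place of tert-butoxycarbonyl gives a 2.0-fold lower number from compound 1 to compound 3 (0.29 log units; within the scatter) in this assay. Within the data shown here, this is the first reading at this position, since the earlier step changed only the nonyl group, and it shows that a carbamate-free aromatic ring and the original group cannot be told apart here, even though the 2 hydrogen-bond acceptors leave with the tert-butoxycarbonyl.

From the compounds shown here alone, whether a smaller group on this nitrogen, such as methyl or acetyl, or a bare amine hydrogen would read the same remains open, as does the same swap on the core of compound 2. Nothing available explains the result.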